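This account rests on a few compounds, and the source may have more. Where it says the series, first, only, none or still open, it means among the compounds named here.

Compound 1 `COc1cc(NC(C)CCCNC(=O)NCCCO)c2ncccc2c1`: > 100000 nM
Compound 2 `COc1cc(NC(C)CCCNC(=O)NCCCCCO)c2ncccc2c1`: 200 nM

Both compounds were tested in a functional assay on SW-620 cells (Homo sapiens); a higher number here means a weaker inhibitor, a lower number a stronger inhibitor. The entry for compound 1 is a limit and not a number: the limit of > 100000 nM in this assay, at which 1 of the 2 values shown sits. Going by the values given here, compound 2 gives 200 nM, the only true number so far.

The next compound, compound 3 `COc1cc(NC(C)CCCNC(=O)NOCc2ccccc2)c2ncccc2c1`, differs from compound 2 by benzyloxy in place of 5-hydroxypentyl on an amide-type nitrogen. Among the compounds with values here, only one measured step bears on this change, an at least 500-fold lower number from compound 1 to compound 2 (2.69 log units; beyond the scatter). It is a large step. That change, too, lies in the group on an amide-type nitrogen, but it only altered the chain and brought in no ring. It suggests that this assay can respond strongly to this group, but it says nothing directly about benzyloxy. With the 5-hydroxypentyl of compound 2 at 200 nM lost, a clear move toward a weaker inhibitor seems more likely than a gain. The expected step is a 15-fold higher number from compound 2 to compound 3 (1.18 log units; beyond the scatter), with wide uncertainty. For compound 3 the estimated value is 3000 nM, with an expected range from 300 nM to 30000 nM.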

Compound 3, half-maximal inhibitory concentration: 20000 nM
The estimate for compound 3 lay 6.7-fold (0.82 log units) below the measured number, and the stated range covers the measured number.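

In this assay, going by these compounds alone, the group on the amide-type nitrogen now carries a ring for the first time, and benzyloxy does not match 5-hydroxypentyl, giving a 100-fold higher number from compound 2 to compound 3 (2.00 log units; beyond the scatter). Benzyloxy still does better than 3-hydroxypropyl, with an at least 5.0-fold lower number from compound 1 to compound 3 (0.69 log units; beyond the scatter), so a chain is not the only kind of group tolerated here, and compound 3 falls between the other two compounds. The entry for compound 1 is a limit and not a number, so this second step gives only the least size it can have: the limit of > 100000 nM in this assay, at which 1 of the 3 values shown sits.

Compound 3 alters the chain, the hydroxy and the ring in one change, so the compounds shown cannot say which of these accounts for its step from compound 2, and a plain benzyl group or a phenyl ring carried on a pentyl chain would be needed to separate them. As far as these compounds go, whether a chain longer than 5-hydroxypentyl, or a pentyl chain without its hydroxy, would give a lower number than compound 2 also stays open.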